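The source may hold more compounds than are shown below. What is called first, only, known or untested is meant among the compounds shown, and "the series" means these compounds.

Measured compounds:
Compound 1, `O=C(CN(c1ncnc2c1ncn2C1CCCCO1)C1CC1)N[C@@H](CCC(=O)OCc1ccccc1)C(=O)OCc1ccccc1`: in a functional assay on the whole organism (Tail, strain ICR) with Mus musculus as the target, in the tail flick test, with a stated time of 90 min, at a dose of 25 umol/kg by the oral route (a lower number here means a weaker effect, a higher number a stronger effect of the compound at the dose given), compound 1 gives 25.2%
Compound 2, `CC[C@H](C)[C@H](NC(=O)CN(c1ncnc2c1ncn2C1CCCCO1)C1CC1)C(=O)OCc1ccccc1`: compound 2 gives 22.6%
Compound 3, `CC(C)(C)OC(=O)NCCCC[C@H](NC(=O)CN(c1ncnc2c1ncn2C1CCCCO1)C1CC1)C(=O)OCc1ccccc1`: compound 3 gives 32.9%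

All three share the same core and differ only in the side group on the amino-acid part. Compound 3 has the largest of the three numbers, yet its distance from compound 1 is small: a number 7.7 percentage points higher from compound 1 to compound 3 (within the scatter). Only compound 2 sits clearly apart from it, since a number 10.3 percentage points higher from compound 2 to compound 3 (beyond the scatter). The step of a number 2.6 percentage points lower from compound 1 to compound 2 (within the scatter) shows that the two smaller side groups give readings that cannot be told apart.

Compound 4, `CC(C)[C@H](NC(=O)CN(c1ncnc2c1ncn2C1CCCCO1)C1CC1)C(=O)OCc1ccccc1`, is not yet measured. It differs from compound 3 as follows: isopropyl in place of 4-((tert-butoxycarbonyl)amino)butyl on a saturated chain carbon bound to an amide-type nitrogen and a carbonyl carbon. This change closely mirrors the measured step from compound 2 to compound 3 run backwards, so the expectation is that losing the longer chain returns the reading to the level of compounds 1 and 2. The expected step is therefore a number 9.9 percentage points lower from compound 3 to compound 4 (within the scatter), a modest fall. For compound 4 the estimate in this assay is 23%, with a likely range from 14% to 32%.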

Compound 4, a percentage reported as activity, at one dose (the size of the read-out at that dose, not a potency): 30.1%
Compound 4: middle estimate off by 7.1 percentage points, on the low side; low and high end bracket the measured number.
By their numbers in this assay, from the lowest: compounds 2, 1, 4 and 3 (each within the scatter of the next, the first and the last beyond it).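

In this assay, putting isopropyl, with 3 heavy atoms, in place of 4-((tert-butoxycarbonyl)amino)butyl gives a number 2.8 percentage points lower from compound 3 to compound 4 (within the scatter), so on this saturated chain carbon bound to an amide-type nitrogen and a carbonyl carbon, removing most of the side group leaves a reading the scatter cannot separate. The same holds against the two other side groups, with a number 7.5 percentage points higher from compound 2 to compound 4 (within the scatter) where hydrogen replaces methyl, and with a number 4.9 percentage points higher from compound 1 to compound 4 (within the scatter) where isopropyl replaces 2-(benzyloxycarbonyl)ethyl. The only gap beyond the scatter, a number 10.3 percentage points higher from compound 2 to compound 3 (beyond the scatter), therefore cannot be read as a need for the long protected chain, since a side group as small as isopropyl stands within the scatter of both of those compounds.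

From the compounds shown here alone, whether a free amine or a free carboxylic acid on this side chain, or a plain unbranched butyl chain, would read clearly apart from these four remains open. No measurement is at hand that would explain any of these readings.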